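Notes on compounds 1 to 3: efficacy and the aryl substituent

The source may report more compounds than this note shows. Statements on the series, on what has been measured and on what is new or still open speak of the compounds shown alone.

Among the compounds with values here, compound 2 `Cc1cccc(NC(=O)CN2CCC(c3cccc(O)c3)CC2)c1` stands highest of the two compounds measured so far in a functional assay on HEK293 cells for agonist activity at D(4) dopamine receptor (Homo sapiens), read by FLIPR (a lower number here means a smaller maximal response, a higher number a larger maximal response), where compound 2 gives 66%; the nearest value belongs to compound 1 `Cc1cccc(NC(=O)CN2CCC(c3ccccc3)CC2)c1`, which in this assay gives 37%. Within the data shown here, the only measured step, a number 29 percentage points higher from compound 1 to compound 2 (beyond the scatter), shows hydroxy in place of hydrogen on an aromatic carbon raising the maximal response. Compound 3 `Cc1cccc(NC(=O)CN2CCC(c3ccccc3C)CC2)c1` is not yet measured. It differs from compound 2 by 2-methylphenyl in place of 3-hydroxyphenyl on a saturated ring carbon. Among the measured compounds shown here, the hydroxy that separates compound 2 from compound 1 is thus absent in compound 3, and no measured step speaks to the methyl. Because a number 29 percentage points higher from compound 1 to compound 2 (beyond the scatter) bears on this change in reverse, a drop beyond the scatter is expected, of about a number 26 percentage points lower from compound 2 to compound 3 (beyond the scatter). Compound 3 is therefore estimated at 40% in this assay, with a range of 20% to 65%.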

Compound 3, largest response reached (reported as efficacy), in percent of the reference or control that the assay uses: 43%
The estimate for compound 3 lay 3 percentage points below the measured number, within the range that was stated.
By their numbers in this assay, from the lowest: compounds 1 and 3 (each within the scatter of the next); then compound 2.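

In this assay, 2-methylphenyl in place of 3-hydroxyphenyl on the saturated ring carbon does not keep the higher maximal response of compound 2 (a number 23 percentage points lower from compound 2 to compound 3 (beyond the scatter)). Methyl in place of hydrogen on an aromatic carbon does not separate compound 3 from compound 1 (a number 6 percentage points higher from compound 1 to compound 3 (within the scatter)), so among the three compounds only the 3-hydroxyphenyl group of compound 2 stands apart beyond the scatter. No independent data bear on the reason for these numbers.

Still open, from the compounds shown here alone, is whether a methoxy or an amine in place of the hydroxy would hold the maximal response of compound 2. Also open, going by these compounds, is whether the hydroxy would give a similar step from another carbon of the aromatic ring, or alongside the methyl of compound 3.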